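Swapping the basic side chain of compound 1

The compounds below may be only part of what the source reports. "The series", "measured", "known", "first", "only" and "open" are said of these compounds alone.

Compound 1, `c1ccc2c(c1)CN[C@@H](CN(CC[C@@H]1CCCNC1)[C@H]1CCCc3cccnc31)C2`: 161 nM
Compound 2, `c1cnc2c(c1)CCC[C@@H]2N(CCCN1CCNCC1)Cc1nc2ccccc2s1`: 1200 nM
Compound 3, `c1cnc(CN(CCCN2CCNCC2)[C@H]2CCCc3cccnc32)nc1`: 4320 nM

Within the data shown here, in a functional assay on CCRF-CEM cells for antagonist activity at C-X-C chemokine receptor type 4 (Homo sapiens), read by calcium flux, with stated times of 25 min and 90 s (on this read-out lower numbers stand for stronger inhibition and higher numbers for weaker inhibition), compound 1 gives the lowest of the three numbers, with compound 2 well above it and compound 3 higher still; the one measured step is a 3.6-fold higher number from compound 2 to compound 3 (0.56 log units; beyond the scatter). Compound 4, `c1ccc2c(c1)CN[C@@H](CN(CCCCN1CCNCC1)[C@H]1CCCc3cccnc31)C2`, differs from compound 1 by 2-(piperazin-1-yl)ethyl in place of piperidin-3-yl on a saturated chain carbon, two bonds along the chain from an amine nitrogen. Among the measured compounds shown here, no measured pair changes this part of the molecule, and the step from compound 2 to compound 3 concerns a different group on the amine nitrogen, so it offers no direct guide. The new side chain of compound 4 resembles those of compounds 2 and 3, whose numbers both lie well above that of compound 1. A modest rise is therefore expected: a 2.5-fold higher number from compound 1 to compound 4 (0.40 log units; beyond the scatter). Compound 4 is estimated at 400 nM, within 120 nM to 1300 nM.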

Compound 4, half-maximal inhibitory concentration: 66 nM
Estimate against measurement, compound 4: 6.1-fold (0.78 log units) above, outside the stated range (below it).
By their numbers in this assay, from the lowest: compound 4; then compound 1; then compound 2; then compound 3.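

At this place, on a saturated chain carbon two bonds along the chain from an amine nitrogen, 2-(piperazin-1-yl)ethyl is tolerated in place of piperidin-3-yl in this assay, giving a 2.4-fold lower number from compound 1 to compound 4 (0.39 log units; beyond the scatter). The side chain therefore does not need the defined stereocentre of piperidin-3-yl to reach this level of inhibition. No measurement shown here accounts for the step.

On these data alone, the change alters the ring, the chain and the stereocentre together, so their separate contributions remain open. It is also unknown whether a simple primary amine on the chain could replace the piperazine ring.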